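The compounds below may be only part of what the source reports. "The series", "measured", "known", "first", "only" and "open" are said of these compounds alone.

Measured so far in an assay on isolated protein for inhibition of Rho-associated protein kinase 2 (Homo sapiens), read by scintillation counting, radiometric assay and 33P incorporation, with a stated time of 40 min, in the presence of a further agent that is not named here; on this read-out lower numbers stand for stronger inhibition and higher numbers for weaker inhibition: compound 1 `CCCC(=O)Nc1cccc(NC(=O)COc2ccc3c(=O)ccoc3c2)c1` gives 176 nM; compound 2 `N#Cc1ccc(C(=O)Nc2cccc(NC(=O)COc3ccc4c(=O)ccoc4c3)c2)cc1` gives 15 nM.

For the measured compounds named here, on these two numbers compound 2 stands lowest, and the only step available, a 12-fold lower number from compound 1 to compound 2 (1.07 log units; beyond the scatter), is a large one, well beyond the scatter. Compound 3 `COc1ccc(C(=O)Nc2cccc(NC(=O)COc3ccc4c(=O)ccoc4c3)c2)cc1` is the next change, and it differs from compound 2 by methoxy in place of cyano on an aromatic carbon.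

Going by the values given here, the one measured step does not bear directly on this change: it exchanged a propyl for a 4-cyanophenyl on the carbonyl carbon, whereas the change from compound 2 to compound 3 keeps the aryl amide and only swaps the substituent on it. Among the compounds with values here, there is no measured pair in which cyano gives way to methoxy, so the direction of the step rests on little. A modest shift toward a higher number, around the edge of the scatter, is taken as the most plausible outcome in this assay. For compound 3 this means an expected step of a 2.0-fold higher number from compound 2 to compound 3 (0.30 log units; within the scatter). Compound 3 is therefore estimated at 30 nM, with a range from 10 nM to 100 nM.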

Compound 3, half-maximal inhibitory concentration: 7 nM
For compound 3 the middle estimate is 4.3-fold (0.63 log units) above the measured one, and the stated range ends above it.
By their numbers in this assay, from the lowest: compound 3; then compound 2; then compound 1.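

In this assay, the substituent on the aromatic carbon para to a large group affects the number, with a 2.1-fold lower number from compound 2 to compound 3 (0.33 log units; beyond the scatter) as a modest step beyond the scatter, even though cyano and methoxy each hold 2 heavy atoms and 1 hydrogen-bond acceptor. The large drop on going from propyl to an aryl group on the carbonyl carbon is therefore not confined to the 4-cyanophenyl amide, since 4-methoxyphenyl also gives a 25-fold lower number from compound 1 to compound 3 (1.40 log units; beyond the scatter) and so extends the gain seen in a 12-fold lower number from compound 1 to compound 2 (1.07 log units; beyond the scatter) on the same carbonyl carbon. No supporting evidence is available to account for either step.

With only two substituents at this position, the compounds shown give no trend across groups, and how a phenyl without a substituent, a hydroxy, a dimethylamino or a carboxylic acid would compare there remains open. Also open, as far as these compounds go, are whether methoxy would keep its number at the other ring positions and whether a longer alkoxy chain, such as ethoxy or propoxy, would lower the number further.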